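The source may report more compounds than this note shows. Statements on the series, on what has been measured and on what is new or still open speak of the compounds shown alone.

Compound 1 `Nc1nc2ccccn2c1-c1ccc(O)cc1` is the reference of this set. In an assay on isolated protein for inhibition of ubiquitin carboxyl-terminal hydrolase 47 (Homo sapiens) (on this read-out higher numbers stand for weaker inhibition and lower numbers for stronger inhibition), compound 1 gives > 100000 nM, which is a limit of the assay and not a number. Compound 2 `CN(C)c1nc2ccccn2c1-c1ccc(O)cc1` also sits at a limit in this assay, with > 100000 nM. Compound 3 `CC(C)Nc1nc2ccccn2c1-c1ccc(O)cc1` likewise gives only a limit in this assay, > 100000 nM. The three measured steps, a step that the two limits leave unreadable from compound 1 to compound 2, a step that the two limits leave unreadable from compound 1 to compound 3 and a step that the two limits leave unreadable from compound 2 to compound 3, therefore carry no readable size because of the limit of > 100000 nM in this assay, at which 3 of the 3 values shown sit. Compound 4 `Nc1nc2cc(C(F)(F)F)ccn2c1-c1ccc(O)cc1` differs from compound 1 by trifluoromethyl in place of hydrogen on an aromatic carbon. Going by the values given here, none of the measured steps touches this position, so no direction can be taken from them for this assay. Compound 4 is therefore expected to sit near the same limit, with an estimate of 200000 nM and a range from 50000 nM to 1000000 nM, meaning an expected step that the limit leaves unreadable from compound 1 to compound 4.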

Compound 4, half-maximal inhibitory concentration: > 100000 nM
Compound 4 was reported as a limit (the forecaster's own chance of this, stated with the estimate: 85%); the middle value lies beyond the limit too.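

Compound 4, like compound 1, stands at a limit in this assay, so no step between them can be read: the limit of > 100000 nM in this assay, at which 4 of the 4 values shown sit.

The compounds shown leave open which change to the shared core, if any, gives a readable value in this assay.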